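This account rests on a few compounds, and the source may have more. Where it says the series, first, only, none or still open, it means among the compounds named here.

Measured so far in an ADME assay on RAW264.7 cells (Mus musculus) for cytotoxicity, read by MTT assay, with a stated time of 48 h; a lower number here means a stronger inhibitor, a higher number a weaker inhibitor:
Compound 1 `CCS(=O)(=O)Nc1ccc(NC(=O)c2cc(C(F)(F)F)cc(C(F)(F)F)c2)cc1C` gives 124000 nM.
Compound 3 `CS(=O)(=O)Nc1ccc(NC(=O)c2cc(C(F)(F)F)cc(C(F)(F)F)c2)cc1Cl` gives 69600 nM.
Compound 2 `CCS(=O)(=O)Nc1ccc(NC(=O)c2cc(C(F)(F)F)cc(C(F)(F)F)c2)cc1OC` reaches only a limit of this assay, > 250000 nM.

Compound 3 holds the lower of the two numbers in this assay, with compound 1 at a distance within the scatter; the two differ in more than one place, so their values show only that they lie close together. Compound 4 `CCS(=O)(=O)Nc1ccc(NC(=O)c2cc(C(F)(F)F)cc(C(F)(F)F)c2)cc1Cl` differs from compound 3 by methyl in place of hydrogen on a saturated chain carbon bound to a sulfonyl sulfur. Within the data shown here, the single measured step, an at least 2.0-fold higher number from compound 1 to compound 2 (0.30 log units; that floor lies within the scatter), concerns a ring substituent and ends at the limit (the limit of > 250000 nM in this assay, at which 1 of the 3 values shown sits); it does not bear on a change at the sulfonyl chain. Among the measured compounds shown here, no measured step touches that chain. The expectation is therefore a step of a 1.0-fold higher number from compound 3 to compound 4 (0.00 log units; within the scatter), none beyond the scatter. Compound 4 is estimated at 70000 nM, between 30000 nM and 170000 nM.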

Compound 4, half-maximal inhibitory concentration: 64100 nM
Compound 4: the middle estimate sits 1.1-fold (0.04 log units) above what was measured; the measured number falls inside the stated range.
By their numbers in this assay, from the lowest: compounds 4, 3 and 1 (each within the scatter of the next). At a limit, above all of these: compound 2.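

In this assay, methyl in place of hydrogen on a saturated chain carbon bound to a sulfonyl sulfur gives a 1.1-fold lower number from compound 3 to compound 4 (0.04 log units; within the scatter), so this change does not separate the methylsulfonyl and ethylsulfonyl compounds. With the ethylsulfonyl chain held constant, chloro in place of methoxy gives an at least 3.9-fold lower number from compound 2 to compound 4 (0.59 log units; beyond the scatter), a step that starts from a limit of the assay and so gives only a floor: the limit of > 250000 nM in this assay, at which 1 of the 4 values shown sits.

Chloro in place of methyl gives a 1.9-fold lower number from compound 1 to compound 4 (0.29 log units; within the scatter), which leaves these two aromatic substituents unseparated. Open, as far as these compounds go, is whether a longer chain or a cyclopropyl group on the sulfonyl sulfur stays within this range, and how an amine on the aromatic carbon compares with chloro.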